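Adding a Substituted Benzyl Ether to Compound 2

The source may hold more compounds than are shown below. What is called first, only, known or untested is meant among the compounds shown, and "the series" means these compounds.

Compound 2 `COc1ccc2c(=O)c(-c3cc(OC)c(OC)cc3OC)coc2c1` gives 9170 nM in a functional assay on HCT-116 cells (Homo sapiens) for antiproliferative activity, read by MTT assay, with a stated time of 24 h (a higher number here means a weaker inhibitor, a lower number a stronger inhibitor), the highest number and thus the weakest of the three measured compounds. Compound 1 `COc1cc(OC)c(-c2coc3cc(OCC=C(C)C)ccc3c2=O)cc1OC` gives 680 nM and compound 3 `COc1cc(OC)c(-c2coc3cc(OCc4ccc(Br)cc4)ccc3c2=O)cc1OC` gives 1980 nM. Compound 4 `COc1cc(OC)c(-c2coc3cc(OCc4ccccc4C(F)(F)F)ccc3c2=O)cc1OC` carries 2-(trifluoromethyl)phenyl in place of hydrogen on a saturated chain carbon bound to an oxygen on an aromatic ring. Among the measured compounds shown here, two measured steps bear on this change: a 4.6-fold lower number from compound 2 to compound 3 (0.67 log units; beyond the scatter) and, read in reverse, a 13-fold higher number from compound 1 to compound 2 (1.13 log units; beyond the scatter); in both, the compound bearing a group on that saturated chain carbon shows the lower number. The substituted phenyl in compound 4 is closest in kind to the change seen in compound 3, so a modest decrease is expected for compound 4, with an estimated step of a 3.7-fold lower number from compound 2 to compound 4 (0.56 log units; beyond the scatter). The estimate for compound 4 is 2500 nM, within 1000 nM to 6000 nM.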

Compound 4, half-maximal inhibitory concentration: 4760 nM
Beside the measured number, compound 4's estimate is 1.9-fold (0.28 log units) below it; the measured number falls inside the stated range.
By their numbers in this assay, from the lowest: compound 1; then compound 3; then compounds 4 and 2 (each within the scatter of the next).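

The step of a 1.9-fold lower number from compound 2 to compound 4 (0.28 log units; within the scatter) shows that a substituted phenyl on this saturated chain carbon need not move the number beyond the scatter, as 4-bromophenyl had done. The identity of the group therefore counts, with a 2.4-fold higher number from compound 3 to compound 4 (0.38 log units; beyond the scatter) when 2-(trifluoromethyl)phenyl replaces 4-bromophenyl and a 7.0-fold higher number from compound 1 to compound 4 (0.85 log units; beyond the scatter) when it replaces 2-methylprop-1-en-1-yl.

From the compounds shown here alone, whether a benzyl group carrying an amine or a carboxylic acid, or a longer chain ending in 2-methylprop-1-en-1-yl, would sit nearer compound 1 or compound 4 stays open. Nothing available accounts for the differences among these groups.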